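Quinolin-8-yl for dichlorophenyl on the hexyl-linked series

A few compounds are considered here, and "the series" means these few. Any claim that something is new, unique, unknown or untested is made for them only; others in the source may bear on it.

Three compounds have numbers in an assay on HEK293 cells for displacement of a labelled ligand from 5-hydroxytryptamine receptor 6 (Homo sapiens), read by radioligand binding; on this read-out lower numbers stand for stronger inhibition and higher numbers for weaker inhibition. Compound 1 `O=c1n(CCCCCCN2CCN(c3cccc(Cl)c3Cl)CC2)nc2ccccn12` gives 299 nM and stands lowest of the three. Compound 3 `O=C(NCCCCCCn1nc2ccccn2c1=O)N1CCN(c2cccc(Cl)c2)CC1`, which carries a urea in place of the direct link between the chain and the ring nitrogen, gives 2550 nM, a number beyond the scatter above that of compound 1. Compound 2 `NC(=O)NCCCCCCN1CCN(c2cccc(Cl)c2)CC1`, with a primary urea at the end of the chain and a single chlorine on the aryl group, gives 4930 nM, the highest number of the set and furthest from compound 1. Among the compounds with values here, no pair of these differs in only one place, so the gaps can only be read as the values show them.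

Compound 4 `O=c1n(CCCCCCN2CCN(c3cccc4cccnc34)CC2)nc2ccccn12` is not yet measured. Relative to compound 1 the change is quinolin-8-yl in place of 2,3-dichlorophenyl on an amine nitrogen in a ring; the rest of the molecule, chain and core included, is unchanged. Nothing in the measured set probes this aryl group, so no step size can be drawn from it. Compound 4 is expected to stay close to compound 1, with a step of a 1.2-fold lower number from compound 1 to compound 4 (0.08 log units; within the scatter) that is not expected to go beyond the scatter. The estimate for compound 4 is 250 nM, within a range from 60 nM to 1200 nM.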

Compound 4, inhibition constant: 4140 nM
Compound 4: middle estimate off by 17-fold (1.22 log units), on the low side; the whole stated range lies below it.
By their numbers in this assay, from the lowest: compound 1; then compounds 3, 4 and 2 (each within the scatter of the next).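

Within the data shown here, on an amine nitrogen in a ring, quinolin-8-yl in place of 2,3-dichlorophenyl gives a 14-fold higher number from compound 1 to compound 4 (1.14 log units; beyond the scatter) in this assay, the only step in the set that changes one place, with the chain and the core held fixed. Among these compounds, the aryl group on this ring nitrogen therefore has a large bearing on the number, which the earlier compounds, differing in more than one place, could not show on their own. The swap removes both chlorines and brings in a second ring, with one ring nitrogen and one hydrogen-bond acceptor, all in a single step, and no measurement here bears on which of these matters.

Still open, from the compounds shown here alone, is whether the higher number follows the ring nitrogen of quinolin-8-yl or the loss of the chlorines, a question that naphthalen-1-yl or 2-chlorophenyl on the same chain and core would help to separate. The compounds shown also leave open whether a step of this size would hold with a butyl chain in place of the present one, or with a methoxy group on the aryl ring.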